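The source may hold more compounds than are shown below. What is called first, only, known or untested is meant among the compounds shown, and "the series" means these compounds.

Working notes on the series, all read in a functional assay on HCT-116 cells (Homo sapiens) for inhibition, read by CCK-8 assay, with a stated time of 72 h, tested at 8 uM; a lower number here means less inhibition of growth, a higher number more inhibition of growth at the concentration tested. Compound 1 (`Nc1ccccc1NC(=O)/C=C/c1ccc(CSc2ccc(Cl)cc2)cc1`) gives 3.27%, compound 2 (`CCc1ccc(SCc2ccc(/C=C/C(=O)Nc3ccccc3N)cc2)cc1`) gives 2.68%, and compound 3 (`Cc1ccc(SCc2ccc(/C=C/C(=O)Nc3ccccc3N)cc2)cc1`) gives 4.93%. Compound 3 therefore stands within the scatter of both neighbours, and the three numbers cannot be ranked.

The next step leads to compound 4 (`Nc1ccccc1NC(=O)/C=C/c1ccc(CSCCc2ccccc2)cc1`), with phenethyl in place of 4-methylphenyl on a sulfur.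

Among the measured compounds shown here, three measured steps bear on this only indirectly. They are a number 1.7 percentage points higher from compound 1 to compound 3 (within the scatter), a number 0.6 percentage points lower from compound 1 to compound 2 (within the scatter) and a number 2.3 percentage points higher from compound 2 to compound 3 (within the scatter), and all lie within the scatter. Each alters only a small substituent on the aromatic ring attached to the sulfur. For the measured compounds named here, none replaces the whole group on the sulfur, so the series holds no direct precedent for this change. The flat response across these steps, starting from the 4.93% of compound 3, gives no reason to expect a real shift in either direction, although the missing precedent keeps the range wide.

The expected change is a number 1.1 percentage points higher from compound 3 to compound 4 (within the scatter), which would be no step beyond the scatter. For compound 4 the estimate is 6%, with an expected range of 0% to 18%.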

Compound 4, percent growth inhibition at one concentration: 10.6%
The estimate for compound 4 lay 4.6 percentage points below the measured number; measured number inside the range.
By their numbers in this assay, from the lowest: compounds 2, 1, 3 and 4 (each within the scatter of the next).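

Among the compounds shown here, this is the first change that replaces the whole group on the sulfur rather than a small substituent on its aromatic ring, and in this assay it still gives no readable shift: phenethyl in place of 4-methylphenyl gives (a number 5.7 percentage points higher from compound 3 to compound 4 (within the scatter)), phenethyl in place of 4-ethylphenyl gives (a number 7.9 percentage points higher from compound 2 to compound 4 (within the scatter)) and phenethyl in place of 4-chlorophenyl gives (a number 7.3 percentage points higher from compound 1 to compound 4 (within the scatter)). The position on the sulfur therefore accepts phenethyl, an aromatic ring carried on a saturated chain, with all three steps staying within the scatter, so the flat response now extends from small ring substituents to exchange of the whole group. No measurement at hand bears on why the numbers fall as they do.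

From the compounds shown here alone, whether any group on the sulfur can produce a step beyond the scatter remains open; a longer chain ending in phenyl, or a chain ending in an amine or a carboxylic acid, would test that. Going by these compounds, with only one concentration read, how these compounds would compare at a higher concentration also remains open.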